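From 3-cyanophenyl to 4-cyanophenyl in an antiproliferative series

This account rests on a few compounds, and the source may have more. Where it says the series, first, only, none or still open, it means among the compounds named here.

Compound 1 `O=C(CCc1cccc2c1B(O)OC2)Nc1cccc(-c2ccc(Cl)cc2)c1` gives 220 nM
Compound 2 `N#Cc1cccc(-c2cccc(NC(=O)CCc3cccc4c3B(O)OC4)c2)c1` gives 120 nM

In a functional assay on SK-OV-3 cells (Homo sapiens) for antiproliferative activity, read by MTT assay, with a stated time of 72 h (on this read-out lower numbers stand for stronger inhibition and higher numbers for weaker inhibition), compound 2 gives 120 nM and stands level with compound 1 within the scatter, the step between them being a 1.8-fold lower number from compound 1 to compound 2 (0.26 log units; within the scatter) and so no real separation. Compound 3 `N#Cc1ccc(-c2cccc(NC(=O)CCc3cccc4c3B(O)OC4)c2)cc1` has the same atoms as compound 2, joined differently, and the change is 4-cyanophenyl in place of 3-cyanophenyl on an aromatic carbon with the group still meta to a large group. In words, 4-cyanophenyl takes the place of 3-cyanophenyl on an aromatic carbon. Going by the values given here, only one measured step bears on this, namely a 1.8-fold lower number from compound 1 to compound 2 (0.26 log units; within the scatter) at that same carbon, and it stayed within the scatter. Among the compounds with values here, no measured pair moves the nitrile alone, so no step beyond the scatter is expected in this assay here. The estimated step is a 1.3-fold higher number from compound 2 to compound 3 (0.10 log units; within the scatter) and would stay within the scatter. For compound 3 the expected value is 150 nM with an estimated range from 60 nM to 400 nM on this read-out.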

Compound 3, half-maximal inhibitory concentration: 340 nM
Compound 3: the middle estimate sits 2.3-fold (0.36 log units) below what was measured; low and high end bracket the measured number.
By their numbers in this assay, from the lowest: compounds 2, 1 and 3 (each within the scatter of the next, the first and the last beyond it).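

Moving the nitrile alone is enough to separate these compounds: in this assay, 4-cyanophenyl in place of 3-cyanophenyl gives a 2.8-fold higher number from compound 2 to compound 3 (0.45 log units; beyond the scatter), a modest step but the only single change here that lies beyond the scatter. Cyano in place of chloro, with the group otherwise unchanged, gives a 1.5-fold higher number from compound 1 to compound 3 (0.19 log units; within the scatter), which stays within the scatter, so among these three compounds the placement of the nitrile registers while that exchange does not. Nothing available accounts for this difference between the two nitrile placements.

As far as these compounds go, it remains open whether 3-chlorophenyl would differ from 4-chlorophenyl as the two cyanophenyl groups do here. From the compounds shown here alone, it is equally open whether a carboxylic acid or an aminomethyl group at either placement would follow the nitrile, and whether the step would persist with a longer chain between the amide and the shared core.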